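This account rests on a few compounds, and the source may have more. Where it says the series, first, only, none or still open, it means among the compounds named here.

Of the compounds shown here, three with a shared sugar-and-base core have been measured in an assay on CHO cells for displacement of a labelled ligand from adenosine receptor A3 (Homo sapiens); on this read-out higher numbers stand for weaker inhibition and lower numbers for stronger inhibition. Compound 1 `CNC(=O)[C@H]1O[C@@H](n2cnc3c(N)nc(Cl)nc32)[C@H](O)[C@@H]1O` gives 0.398 nM, compound 2 `CNc1nc(Cl)nc2c1ncn2[C@@H]1O[C@H](C(=O)NCC2CC2)[C@@H](O)[C@H]1O` gives 1.1 nM, and compound 3 `CNc1nc(Cl)nc2c1ncn2[C@@H]1O[C@H](C(=O)N2CCN(c3ccc(F)cc3)CC2)[C@@H](O)[C@H]1O` gives 2690 nM. Compound 2 thus stands second highest of the three: compound 1 sits lower by a margin beyond the usual scatter, while compound 3 sits far higher.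

Compound 4 `CNc1nc(Cl)nc2c1ncn2[C@@H]1O[C@H](C(=O)NCc2cccc(F)c2)[C@@H](O)[C@H]1O` is still to be measured. It differs from compound 2 by 3-fluorophenyl in place of cyclopropyl on a saturated chain carbon bound to an amide-type nitrogen. Among the measured compounds, replacing a small amide substituent with a larger aryl-bearing one only appears in compound 3, which moves sharply weaker. A smaller move of that kind is expected here: compound 4 is estimated at 10 nM, within 2 nM to 60 nM, an expected step of a 9.1-fold higher number from compound 2 to compound 4 (0.96 log units; beyond the scatter) toward weaker inhibition.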

Compound 4, inhibition constant: 17.4 nM
Compound 4: the middle estimate sits 1.7-fold (0.24 log units) below what was measured, and the stated range covers the measured number.
By their numbers in this assay, from the lowest: compound 1; then compound 2; then compound 4; then compound 3.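

In this assay, 3-fluorophenyl in place of cyclopropyl on a saturated chain carbon bound to an amide-type nitrogen gives a 16-fold higher number from compound 2 to compound 4 (1.20 log units; beyond the scatter), a large step toward weaker inhibition. This one-place comparison shows that the group at this position strongly affects the result, yet compound 4 still gives a measured 17.4 nM with the aromatic ring in place. Nothing available explains the size of this step.

As far as these compounds go, it remains open how much of the step belongs to the ring and how much to the fluorine. A plain benzyl group or a 3-chlorobenzyl group here would help separate the two.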